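Indole for dimethoxyphenyl on the enaminone nitrogen

This account rests on a few compounds, and the source may have more. Where it says the series, first, only, none or still open, it means among the compounds named here.

Three compounds of the series have been run in a functional assay on HCT-116 cells (Homo sapiens) for cytotoxicity, read by MTT assay, with a stated time of 48 h (on this read-out lower numbers stand for stronger inhibition and higher numbers for weaker inhibition), so far, and none has given a number. Compound 1 `COc1ccc(N/C=C\C(=O)c2nc(-c3ccc(C(F)(F)F)cc3)n3ccccc23)cc1OC` reports only a limit there, > 30000 nM, so its position on the read-out is known only as a limit, not as a value. Compound 2 `O=C(/C=C\Nc1cnc2ccccc2c1)c1nc(-c2ccccc2)n2ccccc12` likewise sits at a limit of > 30000 nM in this assay. Compound 3 `COc1ccc(N/C=C\C(=O)c2nc(-c3ccc(F)cc3)n3ccccc23)cc1` also returns a limit, > 30000 nM, in this assay. Taken together, the limit of > 30000 nM in this assay, at which 3 of the 3 values shown sit: every measured member of the series stops at the same limit, so no ranking among compound 1, compound 2 and compound 3 is possible, and no step between measured compounds can be counted.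

Compound 4 `O=C(/C=C\Nc1ccc2[nH]ccc2c1)c1nc(-c2ccc(C(F)(F)F)cc2)n2ccccc12` is the next member, not yet measured in this assay. It differs from compound 1 in one place: 1H-indol-5-yl in place of 3,4-dimethoxyphenyl on an amine nitrogen. For the measured compounds named here, nothing among the measured compounds speaks to this exchange. With all three measured values resting at the limit, the expectation is for no step beyond the scatter, and a step that the limit leaves unreadable from compound 1 to compound 4 is the estimated step from compound 1 to compound 4. Compound 4 is therefore expected at about 40000 nM, within a range of 8000 nM to 200000 nM, with a high chance that only a limit is returned again.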

Compound 4, half-maximal inhibitory concentration: 27100 nM
Compound 4: middle estimate off by 1.5-fold (0.17 log units), on the high side, and the stated range covers the measured number.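

In this assay, for the compounds shown here, compound 4 gives 27100 nM, the first value that is a number and not a limit, so the (1H-indol-5-yl)amino form gives a reading that the (3,4-dimethoxyphenyl)amino form does not. Compound 1 reports > 30000 nM, which is a limit. The exchange of 3,4-dimethoxyphenyl for 1H-indol-5-yl on an amine nitrogen therefore gives an at least 1.1-fold lower number from compound 1 to compound 4 (0.04 log units; that floor lies within the scatter), a floor on the change and not its size, so this one pair shows only that this position tolerates the exchange without a loss that can be seen.

Still open, as far as these compounds go, is whether a pyridine ring or an aminoalkyl chain on the same amine nitrogen would bring the number further down, and whether 1H-indol-5-yl would give a reading on the shared core with the other aryl groups carried by compound 2 and compound 3. With compound 4 the only member off the limit, all other steps in the series cannot be read: the limit of > 30000 nM in this assay, at which 3 of the 4 values shown sit.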